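Swapping the Aryl on the Sulfone for a Pyridine

A few compounds are considered here, and "the series" means these few. Any claim that something is new, unique, unknown or untested is made for them only; others in the source may bear on it.

Compound 1 `COc1cccc(S(=O)(=O)c2ccc(NC(=O)C(C)(O)C(F)(F)F)cc2)c1` — 16000 nM
Compound 2 `CC(O)(C(=O)Nc1ccc(S(=O)(=O)c2cccc(C(F)(F)F)c2)cc1)C(F)(F)F` — > 30000 nM
Compound 3 `CC(O)(C(=O)Nc1ccc(C(=O)c2ccccc2)c(O)c1)C(F)(F)F` — 4200 nM

In a functional assay (Cavia porcellus) with sulfonylurea receptors; K-ATP channels (Homo sapiens) as the target (a higher number here means a weaker inhibitor, a lower number a stronger inhibitor), compound 1 gives 16000 nM. For compound 2 the assay reports only a limit, > 30000 nM, and not a number (the limit of > 30000 nM in this assay, at which 1 of the 3 values shown sits). Compound 3 gives 4200 nM, a lower number than compound 1, and that gap lies beyond the scatter. Among the two compounds with a number, compound 1 therefore stands at the higher end.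

Compound 4 `CC(O)(C(=O)Nc1ccc(S(=O)(=O)c2ccccn2)cc1)C(F)(F)F` differs from compound 1 in one place: pyridin-2-yl in place of 3-methoxyphenyl on a sulfonyl sulfur. Going by the values given here, the only measured step that touches the group on the sulfonyl sulfur is an at least 1.8-fold higher number from compound 1 to compound 2 (0.27 log units; that floor lies within the scatter), and it moves toward the limit of the assay. Among the compounds with values here, no measured pair shows what a pyridin-2-yl does at this position, so the expectation rests on that one step and on the modest size of the change. The step from compound 1 to compound 4 is therefore expected to be small, a 1.3-fold higher number from compound 1 to compound 4 (0.10 log units; within the scatter), leaning weaker rather than stronger. Compound 4 is estimated at 20000 nM, with a range from 8000 nM to 40000 nM.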

Compound 4, half-maximal inhibitory concentration: 600 nM
Estimate against measurement, compound 4: 33-fold (1.52 log units) above; measured number outside the range, below it.
By their numbers in this assay, from the lowest: compound 4; then compound 3; then compound 1. At a limit, above all of these: compound 2.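

In this assay, the group on the sulfonyl sulfur proves able to move the number a long way: a 27-fold lower number from compound 1 to compound 4 (1.43 log units; beyond the scatter). Going by these compounds alone, the only earlier step at this position, an at least 1.8-fold higher number from compound 1 to compound 2 (0.27 log units; that floor lies within the scatter), pointed the other way, and its floor stayed within the scatter, so it gave no sign of a change this large toward stronger inhibition. Pyridin-2-yl, a six-membered aromatic ring with a hetero atom, now shows that replacing the 3-methoxyphenyl ring can matter far more than that first step suggested, although nothing here bears on why the number falls so far.

Going by these compounds, whether the drop belongs to the ring nitrogen itself or simply to the loss of the methoxy group stays open, and a plain phenyl ring on the sulfonyl sulfur would separate the two. Also open, on these data alone, is whether the place of the nitrogen in the ring matters, a question that pyridin-3-yl and pyridin-4-yl would answer, and whether a pyrimidin-2-yl ring, with a second nitrogen, would take the number lower still.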